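Triazole for imidazole on the para-substituted benzyl arm

The source may hold more compounds than are shown below. What is called first, only, known or untested is meant among the compounds shown, and "the series" means these compounds.

Compound 1 `Cc1cc(C)c(NC(=O)N(Cc2ccc(-c3cccnc3)cc2)C2CCCCCC2)c(C)c1`: 0.58 mg/kg
Compound 2 `Cc1cc(C)c(NC(=O)N(Cc2ccc(-n3ccnc3)cc2)C2CCCCCC2)c(C)c1`: > 1 mg/kg

In a functional assay on a cell-free system (plasma) with sterol O-acyltransferase, Soat (Rattus norvegicus) as the target (on this read-out higher numbers stand for an effect only at larger amounts of compound and lower numbers for an effect already at smaller amounts), compound 1 gives 0.58 mg/kg. For compound 2 this assay reports only a limit, > 1 mg/kg. The measured step of an at least 1.7-fold higher number from compound 1 to compound 2 (0.23 log units; that floor lies within the scatter) therefore has only a floor, set by the limit of > 1 mg/kg in this assay, at which 1 of the 2 values shown sits. Compound 3 `Cc1cc(C)c(NC(=O)N(Cc2ccc(-n3nccn3)cc2)C2CCCCCC2)c(C)c1` differs from compound 2 by 2H-1,2,3-triazol-2-yl in place of 1H-imidazol-1-yl on an aromatic carbon. Going by the values given here, no measured step tests this change directly; the single measured step, an at least 1.7-fold higher number from compound 1 to compound 2 (0.23 log units; that floor lies within the scatter), concerns a different ring and sits within the scatter at its floor. The step that the limit leaves unreadable from compound 2 to compound 3 is therefore expected to stay within the scatter. Compound 3 is estimated at 1.5 mg/kg, with a range from 0.5 mg/kg to 5 mg/kg.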

Compound 3, dose for half-maximal effect: > 1 mg/kg
Compound 3: a limit, no number; the forecaster's own chance of this, stated with the estimate: 55%; the middle value lies beyond the limit too.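

In this assay compound 3 gives > 1 mg/kg, a limit and not a number, so 2H-1,2,3-triazol-2-yl yields no more of a reading at this place than 1H-imidazol-1-yl did. Set against pyridin-3-yl, the change gives an at least 1.7-fold higher number from compound 1 to compound 3 (0.23 log units; that floor lies within the scatter), so it too offers only a floor, and the step between the two five-membered rings cannot be read. The limit governs what can be said here: the limit of > 1 mg/kg in this assay, at which 2 of the 3 values shown sit.

Going by these compounds, whether either five-membered ring truly differs from pyridin-3-yl stays open. So does how an amine or a carboxylic acid would read on this aromatic carbon.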